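A few compounds are considered here, and "the series" means these few. Any claim that something is new, unique, unknown or untested is made for them only; others in the source may bear on it.

Compound 1 `CN1CCN(c2ccc(S(=O)(=O)Oc3cccc(Cl)c3)cc2)C1=O` serves as the reference point of this small set. In a functional assay on MCF7 cells (Homo sapiens) for antiproliferative activity, read by sulforhodamine B assay, with a stated time of 48 h (on this read-out lower numbers stand for stronger inhibition and higher numbers for weaker inhibition), compound 1 gives 2200 nM. Compound 2 `CN1CCN(c2ccc(S(=O)(=O)Oc3cccc(Br)c3)cc2)C1=O` differs from it by bromo in place of chloro on an aromatic carbon, and in this assay compound 2 gives 1500 nM, a step of a 1.5-fold lower number from compound 1 to compound 2 (0.17 log units; within the scatter). Compound 3 `CCN1CCN(c2ccc(S(=O)(=O)Oc3cccc(Cl)c3)cc2)C1=O` carries an altered core, differing from compound 1 by methyl in place of hydrogen on a saturated chain carbon bound to an amide-type nitrogen in a ring; in this assay compound 3 gives 5400 nM, a step of a 2.5-fold higher number from compound 1 to compound 3 (0.39 log units; beyond the scatter), which leaves compound 3 with the highest number of the three measured compounds. Compound 4 `CCN1CCN(c2ccc(S(=O)(=O)Oc3cccc(Br)c3)cc2)C1=O`, not yet measured, differs from compound 3 by bromo in place of chloro on an aromatic carbon. This is the same change that turned compound 1 into compound 2, now made on the core of compound 3 rather than that of compound 1. The earlier instance gave a 1.5-fold lower number from compound 1 to compound 2 (0.17 log units; within the scatter), a step that sits within the scatter. On that basis, in this assay a step of a 1.4-fold lower number from compound 3 to compound 4 (0.15 log units; within the scatter) is expected, a shift no larger than the one already seen. Compound 4 is accordingly estimated at 3800 nM in this assay, with a likely range from 1800 nM to 8000 nM.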

Compound 4, half-maximal inhibitory concentration: 2500 nM
Estimate against measurement, compound 4: 1.5-fold (0.18 log units) above, within the range that was stated.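

In this assay, for the compounds shown here, bromo in place of chloro gives a 2.2-fold lower number from compound 3 to compound 4 (0.33 log units; beyond the scatter), and this step agrees with the one seen on the core of compound 1: the same change on two cores in this assay, a 1.5-fold lower number (0.17 log units; within the scatter) from compound 1 to compound 2 and a 2.2-fold lower number (0.33 log units; beyond the scatter) from compound 3 to compound 4, 1.5-fold (0.17 log units) apart, within the scatter of two such steps The added methyl, read with bromo on the aromatic ring, gives a 1.7-fold higher number from compound 2 to compound 4 (0.22 log units; within the scatter), and this step likewise agrees with its counterpart read with chloro: the same change on two cores in this assay, a 2.5-fold higher number (0.39 log units; beyond the scatter) from compound 1 to compound 3 and a 1.7-fold higher number (0.22 log units; within the scatter) from compound 2 to compound 4, 1.5-fold (0.17 log units) apart, within the scatter of two such steps Within this set, each change therefore carries from one core to the other without a difference that can be told from the scatter, but this rests on only two instances of each change and does not show that either step would hold on any further core.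

The compounds shown leave open how a fluoro, methoxy or nitrile group would read in place of the chloro or bromo. They also leave open whether a longer chain, such as propyl or butyl, on the amide-type nitrogen in the ring would continue the step seen with the added methyl.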